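Swapping benzoyl for an aminoacyl chain on a pyrazoline

This account rests on a few compounds, and the source may have more. Where it says the series, first, only, none or still open, it means among the compounds named here.

Measured compounds:
Compound 1 `CC[N+](C)(CC)CC(=O)N1N=C(C)CC1c1ccccc1OC` gives 4170 nM in a functional assay on PC-3 cells (Homo sapiens) for cytotoxicity, read by MTT assay, with a stated time of 48 h; a higher number here means a weaker inhibitor, a lower number a stronger inhibitor.
Compound 2 `O=C(c1ccccc1)N1N=C(c2cc3ccccc3oc2=O)CC1c1ccccc1` gives 5870 nM in this assay.

Of the compounds shown here, two have been measured so far. Compound 2 carries a benzoyl group on the ring nitrogen of the shared core, and in this assay compound 2 gives 5870 nM. Compound 1, which instead carries a charged aminoacyl chain, gives 4170 nM. These two numbers lie within the usual scatter of each other, so neither compound can be called the stronger or weaker inhibitor on this evidence.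

Compound 3 `CCNCC(=O)N1N=C(c2cc3ccccc3oc2=O)CC1c1ccccc1` has not yet been measured. It keeps the core of compound 2 and changes only the acyl group: (ethylamino)methyl in place of phenyl on a carbonyl carbon. Within the data shown here, no measured pair shows the effect of this exact change, so any expectation rests on the two numbers above. Compound 1 shows that an aminoacyl chain in this place gives a number in the same range as the benzoyl of compound 2, which suggests that the step from compound 2 to compound 3 is expected to be small, a 1.5-fold lower number from compound 2 to compound 3 (0.17 log units; within the scatter), possibly none beyond the scatter. Compound 3 is therefore expected to give about 4000 nM in this assay, within a range from 1500 nM to 12000 nM.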

Compound 3, half-maximal inhibitory concentration: 5580 nM
Compound 3: middle estimate off by 1.4-fold (0.14 log units), on the low side; the measured number falls inside the stated range.
By their numbers in this assay, from the lowest: compounds 1, 3 and 2 (each within the scatter of the next).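

Among these compounds, on the carbonyl carbon attached to an amide-type nitrogen in a ring, placing (ethylamino)methyl where phenyl stood gives a 1.1-fold lower number from compound 2 to compound 3 (0.02 log units; within the scatter) in this assay with the rest of the molecule unchanged, the first direct reading of a single swap at this position. A six-membered aromatic ring of carbon only and an open chain with one nitrogen, carrying a hydrogen-bond donor and acceptor that phenyl lacks, therefore cannot be told apart in this pair. Nothing measured here explains this outcome.

As far as these compounds go, what other groups on this carbonyl carbon would give remains open: a (diethylamino)methyl group, a longer chain ending in a primary amine, or a chain ending in a carboxylic acid could each test whether the result extends beyond this one pair. From the compounds shown here alone, it is also open whether the same swap would give so small a step on a different core, or in other cell lines, as a single pair in a single assay cannot settle either question.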